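A few compounds are considered here, and "the series" means these few. Any claim that something is new, unique, unknown or untested is made for them only; others in the source may bear on it.

Compound 3 `O/N=C(\CCN1CCN(c2ccccn2)CC1)c1cccc(Cl)c1` has the lowest of the three numbers measured in a functional assay on HEK293 cells with D(4) dopamine receptor (Homo sapiens) as the target, read by FLIPR (a higher number here means a larger maximal response, a lower number a smaller maximal response), where compound 3 gives 73%, though all three lie within the scatter of one another. Its nearest neighbour is compound 1 `O/N=C(\CCN1CCN(c2ccccn2)CC1)c1ccccc1Cl`, which in this assay gives 74%; the step of a number 1 percentage points lower from compound 1 to compound 3 (within the scatter) lies within the scatter. Compound 2 `Cc1ccccc1/C(CCN1CCN(c2ccccn2)CC1)=N/O` gives 82% in this assay, and the step of a number 9 percentage points lower from compound 2 to compound 3 (within the scatter) is also within the scatter, so the three measured compounds cannot be told apart on this read-out. Compound 4 `N#Cc1cccc(/C(CCN2CCN(c3ccccn3)CC2)=N/O)c1` is not yet measured. The change from compound 3 to compound 4 is cyano in place of chloro on an aromatic carbon. For the measured compounds named here, no measured step brings in a cyano group, so the closest comparison is the exchange of one small group on an aromatic carbon, a number 8 percentage points higher from compound 1 to compound 2 (within the scatter), which stayed within the scatter, as did the two steps that shifted the chloro group. The expectation for compound 4 is therefore a step of no change at the digits printed from compound 3 to compound 4 (within the scatter), meaning nothing beyond the scatter. Compound 4 is estimated to give 73% in this assay, with a likely range from 60% to 86%.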

Compound 4, largest response reached (reported as efficacy), in percent of the reference or control that the assay uses: 48%
Compound 4: middle estimate off by 25 percentage points, on the high side; the measured number lies below the stated range.
By their numbers in this assay, from the lowest: compound 4; then compounds 3, 1 and 2 (each within the scatter of the next).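

For the compounds shown here, at this place on the ring, an aromatic carbon meta to a large group, the identity of the substituent matters in this assay: cyano in place of chloro gives a number 25 percentage points lower from compound 3 to compound 4 (beyond the scatter), the first step here to go beyond the scatter. The other two comparisons point the same way, with a number 26 percentage points lower from compound 1 to compound 4 (beyond the scatter) and a number 34 percentage points lower from compound 2 to compound 4 (beyond the scatter), so compound 4 stands apart from three compounds that could not be told apart from one another. No measurement at hand explains this drop in maximal response.

From the compounds shown here alone, it remains open whether other groups at this carbon, such as a methoxy group, an amine or a carboxylic acid, would lower the response as well or leave it near that of compound 3. Going by these compounds, it is also open whether cyano on another carbon of the ring would have the same effect.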